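Compound 4: 2,4,6-trichlorophenyl for 2,4-dimethylphenyl

The compounds below may be only part of what the source reports. "The series", "measured", "known", "first", "only" and "open" are said of these compounds alone.

In a functional assay on M21 cells (Homo sapiens) for antiproliferative activity, read by sulforhodamine B assay, with a stated time of 48 h (a higher number here means a weaker inhibitor, a lower number a stronger inhibitor), compound 3 `CCCN1CCN(c2ccc(S(=O)(=O)Oc3ccc(C)cc3C)cc2)C1=O` gives 9700 nM, the higher of the two exact numbers, and compound 1 `CN1CCN(c2ccc(S(=O)(=O)Oc3c(Cl)cc(Cl)cc3Cl)cc2)C1=O` sits lower at 1700 nM. Compound 2 `CCCN1CCN(c2ccc(S(=O)(=O)Oc3ccccc3C)cc2)C1=O` reports only a limit, > 100000 nM. Going by the values given here, the one measured step, an at least 10-fold lower number from compound 2 to compound 3 (1.01 log units; beyond the scatter), is large and involves methyl in place of hydrogen on an aromatic carbon. Compound 4 `CCCN1CCN(c2ccc(S(=O)(=O)Oc3c(Cl)cc(Cl)cc3Cl)cc2)C1=O` brings 2,4,6-trichlorophenyl in place of 2,4-dimethylphenyl on an oxygen. That measured step shows that the number in this assay can move strongly with this group, and compound 1, at 1700 nM, already carries 2,4,6-trichlorophenyl. The expected change, towards a lower number and beyond the scatter, is a 6.5-fold lower number from compound 3 to compound 4 (0.81 log units; beyond the scatter). For compound 4 the estimate is 1500 nM, with an expected range of 400 nM to 6000 nM.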

Compound 4, half-maximal inhibitory concentration: 56000 nM
Estimate against measurement, compound 4: 37-fold (1.57 log units) below; measured number above the stated range.
By their numbers in this assay, from the lowest: compound 1; then compound 3; then compound 4. At a limit, above all of these: compound 2.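

In this assay, with 2,4,6-trichlorophenyl held on the oxygen, ethyl in place of hydrogen on a saturated chain carbon bound to an amide-type nitrogen in a ring gives a 33-fold higher number from compound 1 to compound 4 (1.52 log units; beyond the scatter), a large step, so the number depends strongly on that chain. With that chain held, 2,4,6-trichlorophenyl in place of 2,4-dimethylphenyl gives a 5.8-fold higher number from compound 3 to compound 4 (0.76 log units; beyond the scatter), so the group on the oxygen is not favourable in every setting. Compound 2 gives a limit, not a number: the limit of > 100000 nM in this assay, at which 1 of the 4 values shown sits. With that chain held, 2,4,6-trichlorophenyl in place of 2-methylphenyl on an oxygen gives an at least 1.7-fold lower number from compound 2 to compound 4 (0.25 log units; that floor lies within the scatter), so only a floor can be read from this step.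

Open, going by these compounds, is how 2,4-dimethylphenyl behaves on the shorter chain of compound 1. Also open, on these data alone, is whether a longer chain or an amine on that chain moves the number further.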